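Two Methyls on the Nitrogen-Bound Phenyl

The source may hold more compounds than are shown below. What is called first, only, known or untested is meant among the compounds shown, and "the series" means these compounds.

Compound 3 `CCOC(=O)c1c(-c2cc3ccccc3oc2=O)nn(-c2ccccc2)c1C(=O)OCC` stands second highest of three numbers in a functional assay on DU-145 cells (Homo sapiens) for cytotoxicity, read by MTT assay, with a stated time of 48 h (a higher number here means a weaker inhibitor, a lower number a stronger inhibitor), giving 57000 nM. Compound 1 `CCOC(=O)c1c(-c2c(Cl)c3ccccc3oc2=O)nn(-c2ccccc2)c1C(=O)OCC` gives 48000 nM, and compound 2 `CCOC(=O)c1c(-c2c(Cl)c3cc(C)ccc3oc2=O)nn(-c2cccc(C)c2)c1C(=O)OCC`, which also carries methyl groups, gives 103000 nM; both sit within the scatter of compound 3. Compound 4 `CCOC(=O)c1c(-c2cc3ccccc3oc2=O)nn(-c2ccc(C)c(C)c2)c1C(=O)OCC` differs from compound 3 in one place: 3,4-dimethylphenyl in place of phenyl on an aromatic nitrogen. Among the measured compounds shown here, no measured step touches this phenyl alone. For the measured compounds named here, the only measured step, a 1.2-fold higher number from compound 1 to compound 3 (0.07 log units; within the scatter), alters a different ring and stays within the scatter, so it says little about methyl groups. Compound 4 is therefore expected to show a 1.1-fold higher number from compound 3 to compound 4 (0.02 log units; within the scatter) in this assay, nothing beyond the scatter. Compound 4 is estimated at 60000 nM, with a range from 30000 nM to 130000 nM.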

Compound 4, half-maximal inhibitory concentration: 40000 nM
Estimate against measurement, compound 4: 1.5-fold (0.18 log units) above; the range from low to high includes it.
By their numbers in this assay, from the lowest: compounds 4, 1, 3 and 2 (each within the scatter of the next, the first and the last beyond it).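

Within this assay this is the first measured change confined to the phenyl on the aromatic nitrogen: 3,4-dimethylphenyl in place of phenyl gives a 1.4-fold lower number from compound 3 to compound 4 (0.15 log units; within the scatter) and so does not move the number beyond the scatter. At this position, then, the larger group with its two added methyl groups is tolerated in this cell assay. Nothing measured here offers an explanation for this result. On these data alone, whether an amine or a carboxylic acid on this phenyl would shift the number beyond the scatter remains open.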